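From 2-Cyclopropylethynyl to 2-Acetylethyl on the Shared Core

This account rests on a few compounds, and the source may have more. Where it says the series, first, only, none or still open, it means among the compounds named here.

In an ADME assay on TZM cells (Homo sapiens) for cytotoxicity, read by XTT assay, with a stated time of 4 days (on this read-out higher numbers stand for lower toxicity in this test and lower numbers for higher toxicity in this test), compound 1 `Cc1cc(C#N)cc(C)c1Oc1ccc(N)c(Nc2ccc(C#N)cc2)n1` gives 8980 nM and compound 2 `Cc1cc(C#CC2CC2)cc(C)c1Oc1ccc(N)c(Nc2ccc(C#N)cc2)n1` gives 7450 nM on the same read-out. Going by the values given here, the only measured step is a 1.2-fold lower number from compound 1 to compound 2 (0.08 log units; within the scatter) and it leaves compound 2 level with compound 1. Compound 3 `CC(=O)CCc1cc(C)c(Oc2ccc(N)c(Nc3ccc(C#N)cc3)n2)c(C)c1` keeps the shared core and takes 2-acetylethyl in place of 2-cyclopropylethynyl on an aromatic carbon, with 2-acetylethyl in place of 2-cyclopropylethynyl on an aromatic carbon as the counted difference. Among the compounds with values here, only one measured step bears on this change: the same carbon was altered in reaching compound 2, with a 1.2-fold lower number from compound 1 to compound 2 (0.08 log units; within the scatter) as the result. Within the data shown here, no measured compound carries a carbonyl-bearing chain there, so the evidence is thin. On that single step, the expected move is a 1.0-fold higher number from compound 2 to compound 3 (0.00 log units; within the scatter) in this assay and nothing beyond the scatter. The estimate for compound 3 is 7500 nM with a range from 3500 nM to 16000 nM as the expected bounds.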

Compound 3, half-maximal cytotoxic concentration: 9250 nM
Estimate against measurement, compound 3: 1.2-fold (0.09 log units) below; measured number inside the range.
By their numbers in this assay, from the lowest: compounds 2, 1 and 3 (each within the scatter of the next).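

At this aromatic carbon, meta to two methyl groups and para to a large group, this assay now covers three different groups: cyano, 2-cyclopropylethynyl and 2-acetylethyl. Exchanging the ring-bearing chain with its triple bond for an open chain with a carbonyl and a hydrogen-bond acceptor gives a 1.2-fold higher number from compound 2 to compound 3 (0.09 log units; within the scatter), while the change from cyano gives a 1.0-fold higher number from compound 1 to compound 3 (0.01 log units; within the scatter), so neither exchange moves the number beyond the scatter. No measurement available here offers a reason for this.

The compounds shown leave open whether a group of another kind on this carbon, such as an amine or a carboxylic acid, would stay level with these three. They also do not tell whether a longer chain carrying the same carbonyl would do so.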